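Thiourea series on the shared core: cytotoxicity notes

A few compounds are considered here, and "the series" means these few. Any claim that something is new, unique, unknown or untested is made for them only; others in the source may bear on it.

Measured so far:
- compound 1 `NC(=S)N1CCc2c(OCCCCCOc3ccc(Cl)cc3)cccc21` gives > 50000 nM in an ADME assay on Huh-7 cells (Homo sapiens) for cytotoxicity; on this read-out lower numbers stand for higher toxicity in this test and higher numbers for lower toxicity in this test; this is a limit of the assay, not a number.
- compound 2 `O=C(NC(=S)n1ccc2c(OCCCCCOc3ccc(Cl)cc3)cccc21)c1ccccc1` gives 29500 nM in this assay.
- compound 3 `O=C(NC(=S)N1CCc2c(OCc3ccccc3)cccc21)c1ccccc1` gives > 50000 nM in this assay; this is a limit of the assay, not a number.

Where compound 1 stands: only a limit is known for it, and it sits at the limit of > 50000 nM in this assay, at which 2 of the 3 values shown sit. Compound 3 sits at the same limit. Among the compounds with values here, compound 2 is the one compound with a number, and that number is close to the limit.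

The next compound is compound 4 `O=C(NC(=S)N1CCc2c(OCCCCCOc3ccc(Cl)cc3)cccc21)c1cccc([N+](=O)[O-])c1`. It differs from compound 1 by (3-nitrophenyl)carbonyl in place of hydrogen on an amide-type nitrogen. Within the data shown here, no step between two measured compounds has been computed, so the size of the step can only be judged from the three values shown, all of which lie at or close to the same limit.

Expectation for compound 4: its value in this assay is estimated at 40000 nM, with a range from 15000 nM to 100000 nM. The step of an at least 1.2-fold lower number from compound 1 to compound 4 (0.09 log units; that floor lies within the scatter) is expected to be none beyond the scatter, with a fair chance that the assay again reports only the limit.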

Compound 4, half-maximal cytotoxic concentration: 12100 nM
Compound 4: the middle estimate sits 3.3-fold (0.52 log units) above what was measured, and the stated range ends above it.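

In this assay, within the data shown here, (3-nitrophenyl)carbonyl in place of hydrogen on the amide-type nitrogen gives an at least 4.1-fold lower number from compound 1 to compound 4 (0.61 log units; beyond the scatter), the first step that can be read. Among these compounds, it shows that a change at this nitrogen, whose other neighbour is the thiocarbonyl carbon, can bring the read-out off the limit and towards higher toxicity in this test, which the earlier compounds, differing from one another in more than one place, could not show. The size of the step is a floor and not a measured gap, since the value of compound 1 is only a limit: the limit of > 50000 nM in this assay, at which 2 of the 4 values shown sit.

The compounds shown leave open which part of the entering group carries the step, as the carbonyl, the aromatic ring and the nitro group all enter together in this one change. Also open, going by these compounds, is how an acetyl group or a (3-aminophenyl)carbonyl group on the same nitrogen would read in this assay, and so whether the step depends on the nitro group at all.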